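This account rests on a few compounds, and the source may have more. Where it says the series, first, only, none or still open, it means among the compounds named here.

The measured compounds are three.
Compound 1 `CCCC/C=C\c1cn([C@H]2C[C@H](O)[C@@H](CO)O2)c(=O)[nH]c1=O` gives 361 ug/mL in a functional assay on L1210 cells (Mus musculus); on this read-out lower numbers stand for stronger inhibition and higher numbers for weaker inhibition.
Compound 2 `CC#CCc1cn([C@H]2C[C@H](O)[C@@H](CO)O2)c(=O)[nH]c1=O` gives > 1000 ug/mL in this assay.
Compound 3 `O=c1[nH]c(=O)n([C@H]2C[C@H](O)[C@@H](CO)O2)cc1C#CCCCO` gives 280 ug/mL in this assay.

The value of compound 2 is a limit of this assay and not a number. Of the two numbers, compound 1 carries the higher one, but the gap to compound 3, a 1.3-fold lower number from compound 1 to compound 3 (0.11 log units; within the scatter), lies within the scatter, so the two cannot be ordered. Compound 2 stands apart: an at least 2.7-fold higher number from compound 1 to compound 2 (0.44 log units; beyond the scatter), and an at least 3.5-fold lower number from compound 2 to compound 3 (0.55 log units; beyond the scatter), with the limit of > 1000 ug/mL in this assay, at which 1 of the 3 values shown sits, bounding what can be said of it.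

Compound 4 `CCCC#Cc1cn([C@H]2C[C@H](O)[C@@H](CO)O2)c(=O)[nH]c1=O` is not yet measured. It differs from compound 1 in one place: pent-1-yn-1-yl in place of hex-1-en-1-yl on an aromatic carbon. Going by the values given here, two measured steps bear on this. Compound 3 shows that a chain with a triple bond directly on the aromatic carbon leaves the number near that of compound 1, while compound 2 shows that a but-2-yn-1-yl chain weakens inhibition beyond the scatter. Pent-1-yn-1-yl resembles the chain of compound 3 more than that of compound 2, so no step beyond the scatter is expected, though the missing hydroxyl leaves the direction open.

Compound 4 is expected to give about 400 ug/mL, between 150 ug/mL and 1000 ug/mL. The step of a 1.1-fold higher number from compound 1 to compound 4 (0.04 log units; within the scatter) is therefore estimated to lie within the scatter.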

Compound 4, concentration for 50% inhibition: > 1000 ug/mL
Compound 4 was reported as a limit; the forecaster's own chance of this, stated with the estimate: 20%; at least 2.5-fold (0.39 log units) between middle value and limit.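

In this assay, going by these compounds alone, the triple bond directly on the aromatic carbon does not by itself hold the number at this position: hydrogen in place of hydroxy on the saturated chain carbon gives an at least 3.5-fold higher number from compound 3 to compound 4 (0.55 log units; beyond the scatter), a single change that the earlier compounds did not isolate. Pent-1-yn-1-yl in place of hex-1-en-1-yl gives an at least 2.7-fold higher number from compound 1 to compound 4 (0.44 log units; beyond the scatter), so the closeness of the numbers seen earlier for the 5-hydroxypent-1-yn-1-yl and hex-1-en-1-yl chains does not carry over to the chain without the hydroxy group. Compound 2 and compound 4 both carry a limit and not a number, so the step between them cannot be read and the two cannot be ordered: the limit of > 1000 ug/mL in this assay, at which 2 of the 4 values shown sit.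

The compounds shown leave open whether an amine or a carboxylic acid in place of the hydroxy group would keep the number of compound 3. They also leave open whether a longer chain bearing a hydroxy group, or a hydroxy group added to the hex-1-en-1-yl chain of compound 1, would shift the number beyond the scatter.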